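The source may report more compounds than this note shows. Statements on the series, on what has been measured and on what is new or still open speak of the compounds shown alone.

Measured compounds and their values:

Compound 1 `Cc1cccc(NC(=O)CN2CCC(c3nccs3)CC2)c1` — 62%
Compound 2 `Cc1cc(C)cc(C(=O)NCN2CCC(c3cccc[n+]3[O-])CC2)c1` — 56%
Compound 3 `CC(C)Oc1cccc(NC(=O)CN2CCC(c3cccc[n+]3[O-])CC2)c1` — 48%

All three were tested in a functional assay on HEK293 cells for agonist activity at D(4) dopamine receptor (Homo sapiens), read by FLIPR; a lower number here means a smaller maximal response, a higher number a larger maximal response. Compound 1 has the highest number of the three. Compound 2 sits close to it, and the gap between the two lies within the usual scatter, so the two cannot be told apart. Compound 3 lies further down, and its gap to compound 1 is beyond the scatter, so compound 3 gives a clearly smaller maximal response than compound 1.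

Compound 4 `Cc1cccc(NC(=O)CN2CCC(c3ccc(O)cn3)CC2)c1` has not yet been measured. It differs from compound 1 in one place: 5-hydroxypyridin-2-yl in place of 1,3-thiazol-2-yl on a saturated ring carbon. Among the measured compounds shown here, no measured pair in this set shows exactly this exchange, so the size and direction of its effect are not known from the data. The three measured compounds all fall in a fairly narrow band of moderate efficacy, which suggests that a single change of this kind is unlikely to move the number far.

For compound 4 the expected value in this assay is 55%, with a likely range from 35% to 75%. This estimate corresponds to a step of a number 7 percentage points lower from compound 1 to compound 4 (within the scatter), expected to stay within the scatter of the assay.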

Compound 4, largest response reached (reported as efficacy), in percent of the reference or control that the assay uses: 83%
Estimate against measurement, compound 4: 28 percentage points below, outside the stated range (above it).
By their numbers in this assay, from the lowest: compounds 3, 2 and 1 (each within the scatter of the next, the first and the last beyond it); then compound 4.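

In this assay, putting 5-hydroxypyridin-2-yl in place of 1,3-thiazol-2-yl on this saturated ring carbon gives a number 21 percentage points higher from compound 1 to compound 4 (beyond the scatter) and so shows that the group at this position can shift the maximal response by more than the usual scatter. The earlier compounds shown here could not show this, since no two of them differ in only one place. The exchange changes several things at once: a five-membered aromatic ring with 2 hetero atoms gives way to a six-membered aromatic ring with 1 hetero atom, and the count of hydrogen-bond donors goes from 0 to 1, while no measurement here explains why the response rises.

As far as these compounds go, what remains open is which of these differences matters: plain pyridin-2-yl would show what the ring does without the hydroxyl, and 5-methoxypyridin-2-yl would show whether the hydroxyl hydrogen counts or whether any oxygen in that place will do. From the compounds shown here alone, it is also open whether the same exchange raises the response when the rest of the molecule differs, as with the isopropoxy group of compound 3.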